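The source may hold more compounds than are shown below. What is called first, only, known or untested is meant among the compounds shown, and "the series" means these compounds.

Measured so far:
- compound 1, `CC(C)=CCCN(C)C1CCN(CCCc2c[nH]c3ccc(-n4cnnc4)cc23)CC1`, gives 2.6 nM in an assay on CHO cells for displacement of a labelled ligand from 5-hydroxytryptamine receptor 1D (Homo sapiens); a higher number here means a weaker inhibitor, a lower number a stronger inhibitor
- compound 2, `CN(Cc1cccs1)C1CCN(CCCc2c[nH]c3ccc(-n4cnnc4)cc23)CC1`, gives 4.3 nM in this assay

Compound 2 holds the highest of the two numbers measured in this assay, with compound 1 nearest; the gap a 1.7-fold higher number from compound 1 to compound 2 (0.22 log units; within the scatter) lies within the scatter, so the two compounds cannot be ordered on these data.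

Compound 3, `c1cc(CNC2CCN(CCCc3c[nH]c4ccc(-n5cnnc5)cc34)CC2)co1`, has not yet been measured. It differs from compound 2 in one place: ((furan-3-yl)methyl)amino in place of methyl((thiophen-2-yl)methyl)amino on a saturated ring carbon. For the measured compounds named here, only one measured step bears on this change, and it concerns the same position: the step of a 1.7-fold higher number from compound 1 to compound 2 (0.22 log units; within the scatter) exchanged one group on the amine nitrogen for another and moved the number by no more than the scatter. That step, however, kept the methyl on the nitrogen, whereas in compound 3 the methyl is gone and the ring is a different one. Going by the values given here, no measured pair shows what removing the methyl does here, so the expectation for compound 3 rests on the single step alone and carries a wide range.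

On that basis compound 3 is expected to give roughly 8 nM in this assay, between 2.5 nM and 30 nM, which would mean an estimated step of a 1.9-fold higher number from compound 2 to compound 3 (0.27 log units; within the scatter).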

Compound 3, half-maximal inhibitory concentration: 4.5 nM
The estimate for compound 3 lay 1.8-fold (0.25 log units) above the measured number; measured number inside the range.
By their numbers in this assay, from the lowest: compounds 1, 2 and 3 (each within the scatter of the next).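

In this assay, the step of a 1.0-fold higher number from compound 2 to compound 3 (0.02 log units; within the scatter) shows that this position on the saturated ring carbon accepts a change of two features at once: the methyl on the amine nitrogen is absent and a furan-3-yl ring stands where a thiophen-2-yl ring stood, yet the two numbers cannot be told apart. The step of a 1.7-fold higher number from compound 1 to compound 3 (0.24 log units; within the scatter) is also within the scatter, so ((furan-3-yl)methyl)amino, methyl((thiophen-2-yl)methyl)amino and methyl(4-methylpent-3-en-1-yl)amino all give numbers that cannot be separated in these three compounds, none going against this. The entering group also carries a hydrogen-bond donor where the leaving group has none, and in this pair that difference comes with no step beyond the scatter.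

The two features of the change remain unseparated, so the effect of the methyl alone and of the ring alone is open, as is whether a carboxylic acid or a longer chain on this amine nitrogen would stay within the same range. Nothing measured here explains why these groups give such similar numbers.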